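Hydroxy to Methylamino on the Shared Core: an Expected Potency

The source may report more compounds than this note shows. Statements on the series, on what has been measured and on what is new or still open speak of the compounds shown alone.

Of the compounds shown here, two have been measured in an assay on isolated protein for inhibition of LIM domain kinase 1 (Homo sapiens), read by Kinase-Glo, with a stated time of 60 min; a higher number here means a weaker inhibitor, a lower number a stronger inhibitor. Compound 1, `NC(=O)c1sc2ccccc2c1O`, gives only a limit there: its value of > 100000 nM is a limit of the assay rather than a number, as the limit of > 100000 nM in this assay, at which 1 of the 2 values shown sits, records. Compound 2, `Cc1ccc(-c2cc(C(F)(F)F)c3c(N)c(C(N)=O)sc3n2)o1`, is built on a different core and gives 41000 nM in this assay, a weak result. Among the measured compounds shown here, no two measured compounds differ in a single place, so no measured step exists here to guide a prediction. Compound 3, `CNc1c(C(N)=O)sc2ccccc12`, differs from compound 1 by methylamino in place of hydroxy on an aromatic carbon. Without a measured step to lean on, this change is expected to shift the number little, if at all beyond the scatter, and compound 3 is estimated at 100000 nM, within 30000 nM to 300000 nM. The expected step is therefore a number no higher from compound 1 to compound 3 (the limit leaves the size open).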

Compound 3, half-maximal inhibitory concentration: 34000 nM
Beside the measured number, compound 3's estimate is 2.9-fold (0.47 log units) above it; measured number inside the range.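

In this assay, the position on the shared core that holds the hydroxy group of compound 1 proves sensitive to what sits there: methylamino in place of hydroxy on an aromatic carbon gives an at least 2.9-fold lower number from compound 1 to compound 3 (0.46 log units; beyond the scatter). This is the first measured step among these compounds, and it shows that a single change at this place, next to the ring atom that bears a carbamoyl group, can move the number beyond the scatter, even though the counts of hydrogen-bond donors and acceptors stay the same. The full size of the step cannot be given, and the reason is that its starting point is a limit of the assay and not a number: the limit of > 100000 nM in this assay, at which 1 of the 3 values shown sits.

The compounds shown do not tell whether the nitrogen or its methyl matters more. Methoxy, which carries the methyl on oxygen, and dimethylamino would address that question, and how far the number can fall at this position also stays open.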